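Trifluoromethoxy to methoxy on the anilide series

The compounds below may be only part of what the source reports. "The series", "measured", "known", "first", "only" and "open" are said of these compounds alone.

- compound 1 `O=C(CCCCC(S)CCS)Nc1ccccc1`: 9.49%
- compound 2 `O=C(CCCCC(S)CCS)Nc1ccc(OC(F)(F)F)cc1`: 7.27%
- compound 3 `COc1ccc(NC(=O)CCCCC(S)CCS)cc1`: not yet measured

In a functional assay on KB cells (Homo sapiens) for inhibition, read by MTT assay, with a stated time of 24 h, tested at 0.1 ug/mL (on this read-out higher numbers stand for more inhibition of growth at the one concentration tested and lower numbers for less inhibition of growth), compound 2 gives 7.27%, which lies within the scatter of compound 1 at 9.49%. Both values are small at the one concentration tested.

The next change is methyl in place of trifluoromethyl on an oxygen on an aromatic ring.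

For the measured compounds named here, only one measured step bears on this change: a number 2.2 percentage points lower from compound 1 to compound 2 (within the scatter), with trifluoromethoxy in place of hydrogen on an aromatic carbon. That single step gives no sign that this substituent moves the read-out, so no step beyond the scatter is expected here. The expected step is a number 1.2 percentage points higher from compound 2 to compound 3 (within the scatter).

In this assay the estimated value for compound 3 is 8.5%, with an expected range of 2% to 16%.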

Compound 3, percent growth inhibition at one concentration: "not active" (no number reported)
For compound 3 the study gives words and no number; no gap can be computed for the estimate.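

In this assay compound 3 is reported only as "not active", without a number, so no step can be read from compound 2 at 7.27% to compound 3. No measured evidence bears on this result. The compounds shown leave open how far compound 3 actually lies from compound 2 on this read-out.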